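Swapping the aryl arm: bromophenyl to thiophenyl on a cyanopyridine core

This account rests on a few compounds, and the source may have more. Where it says the series, first, only, none or still open, it means among the compounds named here.

Measured so far:
compound 1 `COc1nc(-c2cc3ccccc3o2)cc(-c2ccc3ccccc3c2)c1C#N` — 320000 nM
compound 2 `COc1nc(-c2cc3ccccc3o2)cc(-c2ccc(Br)cc2)c1C#N` — 298000 nM
compound 3 `CCOc1nc(-c2cc3ccccc3o2)cc(-c2ccc(Br)cc2)c1C#N` — 227000 nM

All three numbers come from a functional assay on aorta (strain Wistar) for inhibition, with Thoracic aorta (Rattus norvegicus) as the target; on this read-out higher numbers stand for weaker inhibition and lower numbers for stronger inhibition. The values of compound 1 and compound 2 lie within the usual scatter of each other, even though the two differ in the aryl group on the shared core. Among the measured compounds shown here, compound 3 gives 227000 nM, and its distance from compound 2 and from compound 1 stays within the scatter as well; the one measured step, a 1.3-fold lower number from compound 2 to compound 3 (0.12 log units; within the scatter), did not move the read-out beyond noise.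

Compound 4 `CCOc1nc(-c2cc3ccccc3o2)cc(-c2cccs2)c1C#N` has not been measured. It differs from compound 3 in one place: thiophen-2-yl in place of 4-bromophenyl on an aromatic carbon. For the measured compounds named here, no measured step covers this kind of change; the only comparison at the same position is compound 1 against compound 2, whose values sit within the scatter of each other. On that basis no step beyond the scatter is expected in this assay. Compound 4 is therefore estimated at 250000 nM, with a range from 100000 nM to 600000 nM. The implied step, a 1.1-fold higher number from compound 3 to compound 4 (0.04 log units; within the scatter), is an expectation only.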

Compound 4, half-maximal inhibitory concentration: 308000 nM
Compound 4: middle estimate off by 1.2-fold (0.09 log units), on the low side, and the stated range covers the measured number.
By their numbers in this assay, from the lowest: compounds 3, 2, 4 and 1 (each within the scatter of the next).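

In this assay, among the compounds shown here, the aryl arm opposite the ring nitrogen was changed for the first time in a measured single step, from a six-membered carbon ring bearing bromine to a five-membered aromatic ring with one hetero atom, and this gave a 1.4-fold higher number from compound 3 to compound 4 (0.13 log units; within the scatter). On the ethoxy series, then, replacing 4-bromophenyl with the smaller thiophen-2-yl leaves the read-out within the scatter, so this position has not yet shown any dependence on the aryl group. Nothing available explains this lack of movement.

Going by these compounds, it remains open whether a non-aryl group at this position, such as an amine or a carboxylic acid, would shift the read-out beyond the scatter. On these data alone, it is equally open whether a longer chain in place of the ethoxy group would do so.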